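The source may hold more compounds than are shown below. What is called first, only, known or untested is meant among the compounds shown, and "the series" means these compounds.

Three compounds share one core and differ only in the group attached to an aromatic carbon of the benzene ring that carries the side chain. In a functional assay for activation of Alpha-1B adrenergic receptor (Homo sapiens), read by calcium flux (a higher number here means that more compound is needed for the effect, a lower number that less compound is needed), compound 1 `c1coc(-c2ccccc2NCC2=NCCN2)c1` gives 6.31 nM. Compound 2 `Cc1ccsc1-c1ccccc1NCC1=NCCN1` gives 112 nM in this assay, and compound 3 `c1ccc(-c2cnccn2)c(NCC2=NCCN2)c1` gives 339 nM, the highest number of the three. The steps among them are all beyond the scatter: an 18-fold higher number from compound 1 to compound 2 (1.25 log units; beyond the scatter), a 54-fold higher number from compound 1 to compound 3 (1.73 log units; beyond the scatter) and a 3.0-fold higher number from compound 2 to compound 3 (0.48 log units; beyond the scatter). Compound 4 `CO/N=C(\C)c1ccccc1NCC1=NCCN1` is made from compound 3 by the change (a group of 5 heavy atoms (3 carbon, 1 nitrogen, 1 oxygen; no ring) in place of a group of 6 heavy atoms (4 carbon, 2 nitrogen; one six-membered aromatic ring with 2 hetero atoms), on an aromatic carbon). Every measured step exchanges one aromatic ring for another, so none of them directly tells what an open-chain group does in this place; they only show that the group here matters, with shifts from modest to large. Compound 4 is therefore expected to show a 1.1-fold lower number from compound 3 to compound 4 (0.05 log units; within the scatter) in this assay, with wide uncertainty. The estimate for compound 4 is 300 nM, with a range from 50 nM to 1800 nM.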

Compound 4, half-maximal effective concentration: < 5020 nM
Compound 4: a limit, no number (the forecaster's own chance of this, stated with the estimate: 5%); the middle value does not contradict the limit.
By their numbers in this assay, from the lowest: compound 1; then compound 2; then compound 3.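

Compound 4 gives only a limit, not a number, in this assay: the limit of < 5020 nM in this assay, at which 1 of the 4 values shown sits.

The steps to compound 4 from compound 1, compound 2 and compound 3 therefore cannot be read. The compounds shown leave open how compound 4 ranks against these three, and so what this open-chain group does in place of an aromatic ring.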